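The source may report more compounds than this note shows. Statements on the series, on what has been measured and on what is new or still open speak of the compounds shown alone.

Measured so far in a functional assay on HeLa cells (Homo sapiens) for inhibition, read by MTT assay, with a stated time of 72 h; on this read-out lower numbers stand for stronger inhibition and higher numbers for weaker inhibition:
- compound 1 `COc1cc(OC)c(OC)cc1/C=C/C(=O)c1ccc(O)cc1O`: 37600 nM
- compound 2 `COc1cc(OC)c(OC)cc1/C=C/C(=O)c1ccc(Cl)c([N+](=O)[O-])c1`: 16500 nM
- compound 3 `COc1cc(C(=O)/C=C/c2cc(OC)c(OC)cc2OC)ccc1O`: > 150000 nM, which is a limit of the assay and not a number

Compound 1 stands highest of the two numbers that were obtained; the nearest, compound 2, sits below it by a gap beyond the usual scatter. For compound 3 the result is the limit of > 150000 nM in this assay, at which 1 of the 3 values shown sits. For the measured compounds named here, no two measured compounds differ in one place only, so no single measured step is available, and what the three values show is that the shared core tolerates changes on the ring at the carbonyl without the inhibitory concentration moving far.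

Compound 4 `COc1cc(OC)c(OC)cc1/C=C/C(=O)c1ccc(F)cc1` has not yet been measured. It differs from compound 1 by 4-fluorophenyl in place of 2,4-dihydroxyphenyl on a carbonyl carbon. Compound 2 also lacks the 2,4-dihydroxyphenyl and gives 16500 nM, a lower number than compound 1. On that ground a small lowering is expected, at the edge of the scatter, as the estimated step of a 1.9-fold lower number from compound 1 to compound 4 (0.27 log units; within the scatter). Compound 4 is therefore expected near 20000 nM, with a range from 6000 nM to 60000 nM.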

Compound 4, half-maximal inhibitory concentration: 28600 nM
Compound 4: middle estimate off by 1.4-fold (0.16 log units), on the low side, and the stated range covers the measured number.
By their numbers in this assay, from the lowest: compounds 2, 4 and 1 (each within the scatter of the next, the first and the last beyond it). At a limit, above all of these: compound 3.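

In this assay, 4-fluorophenyl in place of 2,4-dihydroxyphenyl on a carbonyl carbon gives a 1.3-fold lower number from compound 1 to compound 4 (0.12 log units; within the scatter), the first single-place step available in the series. For this pair, a ring with 2 hydrogen-bond donors and a ring with 0 give values that cannot be told apart, so the hydroxy groups of compound 1 are not needed to hold this level of inhibition. This tolerance is claimed for compounds 1 and 4 only, and compound 3 goes against any wider reading, as its result is a limit and not a number: the limit of > 150000 nM in this assay, at which 1 of the 4 values shown sits.

Going by these compounds, whether the tolerance extends to other groups at this place, such as a phenyl ring carrying an amine or a carboxylic acid, remains open. Also open, on these data alone, is what an unsubstituted phenyl or a 4-hydroxyphenyl would give, which would separate the contribution of each substituent.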